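A few compounds are considered here, and "the series" means these few. Any claim that something is new, unique, unknown or untested is made for them only; others in the source may bear on it.

Compound 1, with the structure `O=C(O)COc1ccc([C@H]2CC[C@]3(CC2)OOC2(O3)C3CC4CC(C3)CC2C4)cc1C(=O)O`, is the starting point of this account. In an ADME assay on microsomes from liver (Mus musculus) for metabolic stability, using NADPH, with a stated time of 60 min, in the presence of a further agent that is not named here (on this read-out lower numbers stand for slow clearance and higher numbers for fast clearance), compound 1 gives 8 mL.min-1.g-1. Its nearest neighbour among the measured compounds is compound 3, whose structure is `O=C(O)COc1ccc([C@H]2CC[C@]3(CC2)OOC2(O3)C3CC4CC(C3)CC2C4)cc1Cl` and which in this assay gives 8 mL.min-1.g-1. The step of no change at the digits printed from compound 1 to compound 3 (within the scatter) thus leaves the read-out where it was, and compound 1 stands level with compound 3 at the digits recorded. A third compound, compound 2 with the structure `O=C(O)COc1ccc([C@H]2CC[C@]3(CC2)OOC2(O3)C3CC4CC2CC(C3)C4O)cc1`, in this assay reaches only a limit of the assay, < 7 mL.min-1.g-1. This is the single limit among the three values, (the limit of < 7 mL.min-1.g-1 in this assay, at which 1 of the 3 values shown sits).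

The compound that follows is compound 4, with the structure `O=C(O)c1cc([C@H]2CC[C@]3(CC2)OOC2(O3)C3CC4CC(C3)CC2C4)ccc1O`. It differs from compound 1 in one place: hydrogen in place of carboxymethyl on an oxygen on an aromatic ring. Among the measured compounds shown here, no measured step removes the carboxymethyl from the oxygen on the aromatic ring; the only measured step, no change at the digits printed from compound 1 to compound 3 (within the scatter), concerns the group on an aromatic carbon and was flat within the scatter. For the measured compounds named here, with no step that bears directly on this change and the one available step showing nothing, the expectation for compound 4 is a step of no change at the digits printed from compound 1 to compound 4 (within the scatter), that is, none beyond the scatter. Compound 4 is therefore estimated in this assay at 8 mL.min-1.g-1, within a range from 4 mL.min-1.g-1 to 16 mL.min-1.g-1.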

Compound 4, intrinsic clearance in microsomes: 20 mL.min-1.g-1
Compound 4: middle estimate off by 2.5-fold (0.40 log units), on the low side, outside the stated range (above it).
By their numbers in this assay, from the lowest: compounds 1 and 3 (each within the scatter of the next); then compound 4. At a limit, below all of these: compound 2.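

In this assay, hydrogen in place of carboxymethyl on the oxygen on the aromatic ring gives a 2.5-fold higher number from compound 1 to compound 4 (0.40 log units; beyond the scatter). Among the compounds shown here, this is the first step to go beyond the scatter, whereas chloro in place of carboxy on an aromatic carbon gave no change at the digits printed from compound 1 to compound 3 (within the scatter). The read-out therefore responds to a change at this oxygen in a way the one earlier step did not show, although nothing shown here accounts for the rise.

On these data alone, a single step cannot separate the loss of the carboxymethyl from the presence of the free hydroxy, so it remains open what a methyl or a longer chain ending in a carboxylic acid on the same oxygen would give in this assay. As far as these compounds go, it is also open whether the same change would give a similar step with chloro rather than carboxy on the aromatic carbon, or whether an amine in place of the carboxymethoxy would behave like the hydroxy.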